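Phenyl in Place of Difluorophenyl: A Cautious Forecast

The source may report more compounds than this note shows. Statements on the series, on what has been measured and on what is new or still open speak of the compounds shown alone.

Of the compounds shown here, two built on the same core have been tested in a functional assay on A549 cells (Homo sapiens) for inhibition, read by MTT assay, with a stated time of 48 h; on this read-out lower numbers stand for stronger inhibition and higher numbers for weaker inhibition. Compound 1 `COc1cc(/C=N/Nc2nc(-c3cccc(Br)c3)cs2)cc(Br)c1OC` gives 56000 nM, while compound 2 `COc1cc(/C=N/Nc2nc(-c3ccc(F)c(F)c3)cs2)cc(Br)c1OC` gives 21100 nM. Compound 2 therefore stands lowest of the two numbers, separated from compound 1 by a 2.7-fold lower number from compound 1 to compound 2 (0.42 log units; beyond the scatter).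

Compound 3 `COc1cc(/C=N/Nc2nc(-c3ccccc3)cs2)cc(Br)c1OC` has not been measured. It differs from compound 2 by phenyl in place of 3,4-difluorophenyl on an aromatic carbon. Going by the values given here, the only measured step, from compound 1 to compound 2, swapped one halogen-bearing phenyl for another and moved the number modestly; no measured step removes the halogens entirely. With both measured compounds still carrying halogens on this ring, a modest shift is expected in this assay, more likely toward a higher number than a lower one, amounting to an estimated 1.7-fold higher number from compound 2 to compound 3 (0.22 log units; within the scatter). Compound 3 is accordingly expected to give about 35000 nM, within a range from 12000 nM to 100000 nM.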

Compound 3, half-maximal inhibitory concentration: 40000 nM
Compound 3: middle estimate off by 1.1-fold (0.06 log units), on the low side; the measured number falls inside the stated range.
By their numbers in this assay, from the lowest: compounds 2, 3 and 1 (each within the scatter of the next, the first and the last beyond it).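

In this assay, phenyl in place of 3,4-difluorophenyl gives a 1.9-fold higher number from compound 2 to compound 3 (0.28 log units; within the scatter) and so cannot be told apart from no change on this aromatic carbon. Hydrogen in place of bromo on the phenyl gives a 1.4-fold lower number from compound 1 to compound 3 (0.15 log units; within the scatter) and is likewise within the scatter, so compound 3 shows that a number in this range does not need a halogen on this ring, while the gap between compound 1 and compound 2 is the only one here beyond the scatter. Nothing available explains why these steps are so small.

Still open, as far as these compounds go, is whether a methoxy group, an amine or a carboxylic acid on this phenyl would move the number beyond the scatter. A single fluoro on the phenyl is also untested among the compounds shown, so it remains unclear how much each fluorine of compound 2 contributes.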